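The compounds below may be only part of what the source reports. "The series", "measured", "known", "first", "only" and "open" are said of these compounds alone.

Measured compounds:
- compound 1, `COc1cc2c(Oc3ccc(NC(=O)c4nn(-c5ccccc5)c(=O)c5ccccc45)cc3F)ccnc2cc1OCCCN1CCN(C)CC1`: 1580 nM
- compound 2, `COc1cc2c(Oc3ccc(NC(=O)c4nn(-c5ccc(Br)cc5)c(=O)c5ccccc45)cc3F)ccnc2cc1OCCCN1CCN(C)CC1`: 1370 nM

Going by the values given here, in a functional assay on MDA-MB-231 cells (Homo sapiens) for cytotoxicity, read by MTT assay, with a stated time of 72 h (on this read-out higher numbers stand for weaker inhibition and lower numbers for stronger inhibition), compound 1 gives 1580 nM, the highest of the two numbers measured so far. Its nearest neighbour is compound 2, which gives 1370 nM; the step of a 1.2-fold lower number from compound 1 to compound 2 (0.06 log units; within the scatter) lies within the scatter, so the two values cannot be told apart.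

Compound 3, `COc1cc2c(Oc3ccc(NC(=O)c4nn(-c5ccccc5)c(=O)c5ccccc45)cc3F)ccnc2cc1OCCCN1CCC(C)CC1`, has not yet been measured. It differs from compound 1 in one place: 4-methylpiperidin-1-yl in place of 4-methylpiperazin-1-yl on a saturated chain carbon, three bonds along the chain from an oxygen on an aromatic ring. Among the compounds with values here, the only measured step, a 1.2-fold lower number from compound 1 to compound 2 (0.06 log units; within the scatter), concerns a different part of the molecule, namely bromo in place of hydrogen on an aromatic carbon, and so says nothing about what happens when one of the two ring nitrogens of the chain-end ring becomes a carbon. Within the data shown here, no measured pair shows this kind of change. The step of a 1.1-fold higher number from compound 1 to compound 3 (0.06 log units; within the scatter) that is expected therefore has no clear direction, and a wide range must be allowed around a value close to that of compound 1. For compound 3 the estimate in this assay is 1800 nM, with a range from 600 nM to 5500 nM.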

Compound 3, half-maximal inhibitory concentration: 1480 nM
Compound 3: the middle estimate sits 1.2-fold (0.09 log units) above what was measured, within the range that was stated.
By their numbers in this assay, from the lowest: compounds 2, 3 and 1 (each within the scatter of the next).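

Putting 4-methylpiperidin-1-yl in place of 4-methylpiperazin-1-yl on a saturated chain carbon, three bonds along the chain from an oxygen on an aromatic ring, gives, in this assay, a 1.1-fold lower number from compound 1 to compound 3 (0.03 log units; within the scatter). Going by these compounds alone, this is the first measured pair that touches the chain-end ring, and it shows that, in this one pair, a ring nitrogen can give way to a carbon, leaving one hydrogen-bond acceptor in that group rather than two, with no difference that can be told from the scatter in this cell read-out. Nothing available here explains why the two values cannot be told apart.

Going by these compounds, one pair cannot show how other groups would behave at this position, so it remains open whether a morpholin-4-yl ring, a dimethylamino group or a ring with no methyl group, such as piperidin-1-yl, would also leave the number where it stands. Also open, on these data alone, is whether a longer chain in place of the propyl link between the oxygen and the ring would matter, or whether the same replacement would read the same way on a compound carrying the bromo group of compound 2.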